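The compounds below may be only part of what the source reports. "The series", "measured", "known", "first", "only" and "open" are said of these compounds alone.

Measured so far in a functional assay on HepG2 cells for inhibition of squalene monooxygenase (Homo sapiens); a higher number here means a weaker inhibitor, a lower number a stronger inhibitor:
compound 1 `CCN(C/C=C/C#CC(C)(C)C)Cc1cccc(OCCN(C)S(=O)(=O)c2cccnc2)c1` gives 150 nM
compound 2 `CCN(C/C=C/C#CC(C)(C)C)Cc1cccc(OCCN(C)S(=O)(=O)c2cc(-c3ccsc3)cs2)c1` gives 90 nM
compound 3 `CCN(C/C=C/C#CC(C)(C)C)Cc1cccc(OCCN(C)S(=O)(=O)c2ccc(-c3cccs3)s2)c1` gives 10000 nM

On these numbers compound 1 stands second highest of the three: compound 2 lies within the scatter of it, while compound 3 lies far above it.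

Compound 4 `CCN(C/C=C/C#CC(C)(C)C)Cc1cccc(OCCCS(=O)(=O)c2cccs2)c1` differs from compound 1 by a group of 9 heavy atoms (5 carbon, 2 oxygen, 2 sulfur; one five-membered aromatic ring with 1 hetero atom) in place of a group of 11 heavy atoms (6 carbon, 2 nitrogen, 2 oxygen, 1 sulfur; one six-membered aromatic ring with 1 hetero atom), on a saturated chain carbon, two bonds along the chain from an oxygen on an aromatic ring. The sulfonyl group is thus kept, but the nitrogen of the sulfonamide is gone and a thiophene ring replaces the pyridine ring.

The measured steps concern only the aryl group on the sulfonyl sulfur. The step of a 1.7-fold lower number from compound 1 to compound 2 (0.22 log units; within the scatter) shows that a thiophene-containing aryl on the sulfonyl is tolerated; the step of a 67-fold higher number from compound 1 to compound 3 (1.82 log units; beyond the scatter) shows that another thiophene-containing aryl is not. Going by the values given here, no measured step touches the loss of the sulfonamide nitrogen, so that part of the change is unsupported by the data.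

For compound 4 the expectation is therefore a step of a 2.0-fold higher number from compound 1 to compound 4 (0.30 log units; within the scatter) in this assay, with wide uncertainty, giving an estimate of 300 nM with a range from 60 nM to 2000 nM.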

Compound 4, half-maximal inhibitory concentration: 290 nM
The estimate for compound 4 lay 1.0-fold (0.01 log units) above the measured number, and the stated range covers the measured number.
By their numbers in this assay, from the lowest: compounds 2, 1 and 4 (each within the scatter of the next, the first and the last beyond it); then compound 3.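

Replacing methyl((pyridin-3-yl)sulfonyl)amino with the group of compound 4 gives a 1.9-fold higher number from compound 1 to compound 4 (0.29 log units; within the scatter) in this assay and so shows that the sulfonamide nitrogen and its methyl are not needed to stay within the scatter at this position. The earlier compounds shown here varied only the aryl group on the sulfonyl sulfur, whereas here the group on the saturated chain carbon, two bonds along the chain from an oxygen on an aromatic ring, changes as well. No supporting data bear on why this change is tolerated.

The nitrogen and the aryl group change together in this step, so their separate contributions cannot be read from these compounds. Going by these compounds, whether a carbonyl in place of the sulfonyl group or a longer chain would be accepted at this position also remains open.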